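Sulfonamides of a shared core: a chlorophenyl variant

The source may report more compounds than this note shows. Statements on the series, on what has been measured and on what is new or still open speak of the compounds shown alone.

Measured compounds in a functional assay on M21 cells (Homo sapiens) for antiproliferative activity, read by sulforhodamine B assay, with a stated time of 48 h; a lower number here means a stronger inhibitor, a higher number a weaker inhibitor:
- compound 1 `CCCCCc1ccc(NS(=O)(=O)c2ccc(N3CCNC3=O)cc2)cc1`: 870 nM
- compound 2 `Cc1ccccc1NS(=O)(=O)c1ccc(N2CCNC2=O)cc1`: 150 nM
- compound 3 `COc1ccccc1NS(=O)(=O)c1ccc(N2CCNC2=O)cc1`: 300 nM

Compound 2 gives the lowest number of the three; compound 3 sits within the scatter of it, while compound 1 gives a clearly higher number. Compound 4 `O=C1NCCN1c1ccc(S(=O)(=O)Nc2ccc(Cl)cc2)cc1` has not been measured. It differs from compound 2 in one place: 4-chlorophenyl in place of 2-methylphenyl on a sulfonamide nitrogen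

Going by the values given here, only one measured step changes a group on that same phenyl ring, a 2.0-fold higher number from compound 2 to compound 3 (0.30 log units; within the scatter), and it stayed within the scatter. Among the compounds with values here, no measured step swaps the position or kind of substituent as the change to compound 4 does, so this account rests on that single step alone. The step is therefore expected to be small, a 2.0-fold higher number from compound 2 to compound 4 (0.30 log units; within the scatter), with no direction beyond the scatter claimed. Compound 4 is estimated at 300 nM, between 100 nM and 900 nM.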

Compound 4, half-maximal inhibitory concentration: 90 nM
Compound 4: middle estimate off by 3.3-fold (0.52 log units), on the high side; the measured number lies below the stated range.
By their numbers in this assay, from the lowest: compounds 4, 2 and 3 (each within the scatter of the next, the first and the last beyond it); then compound 1.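

In this assay, the step to a 4-chlorophenyl on the sulfonamide nitrogen stays within the scatter (a 1.7-fold lower number from compound 2 to compound 4 (0.22 log units; within the scatter)), so this site accepts a change in both the kind and the place of the substituent without a clear shift in the number. The same compound stands clearly apart from the other two (a 3.3-fold lower number from compound 3 to compound 4 (0.52 log units; beyond the scatter); a 9.7-fold lower number from compound 1 to compound 4 (0.99 log units; beyond the scatter)). Nothing measured here accounts for these differences. On these data alone, whether an amine or a carboxylic acid on this phenyl ring would keep the number in this range remains open.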